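The source may report more compounds than this note shows. Statements on the series, on what has been measured and on what is new or still open speak of the compounds shown alone.

Measured so far:
compound 1 `c1cncc(-c2ccccc2OCC2=NCCN2)c1`: 109%
compound 2 `c1ccc(-c2cnccn2)c(OCC2=NCCN2)c1`: 97%
compound 3 `c1coc(-c2ccccc2OCC2=NCCN2)c1`: 106%

In a functional assay with Alpha-1A adrenergic receptor (Homo sapiens) as the target, read by calcium flux (on this read-out higher numbers stand for larger maximal responses and lower numbers for smaller maximal responses), compound 3 gives 106%. Among the three numbers this is the second highest; its nearest neighbour is compound 1, with a number 3 percentage points lower from compound 1 to compound 3 (within the scatter), and the furthest is compound 2, with a number 9 percentage points higher from compound 2 to compound 3 (within the scatter), so on this read-out compound 3 is not told apart from either of them. Going by the values given here, the only step beyond the scatter is a number 12 percentage points lower from compound 1 to compound 2 (beyond the scatter), a modest one.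

Compound 4 `c1ccc(-c2ccoc2)c(OCC2=NCCN2)c1` is not yet measured. The change is furan-3-yl in place of furan-2-yl on an aromatic carbon. Among the compounds with values here, no measured step swaps one furan isomer for the other; the steps into compound 3 only exchange a six-membered ring for furan-2-yl and stay within the scatter, while the largest step of all is modest. The maximal response in this assay is therefore expected to stay near that of compound 3, with a step of a number 2 percentage points lower from compound 3 to compound 4 (within the scatter) that is not expected to exceed the scatter. Compound 4 is estimated at 104%, within 90% to 118%.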

Compound 4, largest response reached (reported as maximum), in percent of the reference or control that the assay uses: 104%
Estimate against measurement, compound 4: no gap at the digits printed; measured number inside the range.
By their numbers in this assay, from the lowest: compounds 2, 4, 3 and 1 (each within the scatter of the next, the first and the last beyond it).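

Furan-3-yl in place of furan-2-yl keeps the same atoms and changes only how the ring is joined to the core, and in this assay this gives a number 2 percentage points lower from compound 3 to compound 4 (within the scatter), so the two furan isomers are not told apart on this read-out. Compound 4 also stays within the scatter of the compounds carrying six-membered rings, with a number 7 percentage points higher from compound 2 to compound 4 (within the scatter) and a number 5 percentage points lower from compound 1 to compound 4 (within the scatter), so a furan joined through either ring carbon tested here is not separated from pyridin-3-yl or pyrazin-2-yl. No measured information is available to explain this result.

Every group shown at this position is an aromatic ring, so the effect of an open-chain amine, a carboxylic acid or a longer alkyl chain remains open. The maximal response also leaves open how much of each compound is needed to reach it.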